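Trifluoromethyl in place of chloro: notes towards compound 3

This account rests on a few compounds, and the source may have more. Where it says the series, first, only, none or still open, it means among the compounds named here.

In a functional assay on KYSE-70 cells for antiproliferative activity against KYSE-70 cell line (Homo sapiens), read by MTT assay, with a stated time of 72 h (a lower number here means a stronger inhibitor, a higher number a weaker inhibitor), compound 1 (`O=C(Nc1ccc(Cl)cc1)c1cc(=O)[nH]c2cc(Br)ccc12`) gives > 20000 nM. This value is a limit of the assay and not a number, so compound 1 has no exact place on the scale, and it stands at the limit of > 20000 nM in this assay, at which 1 of the 2 values shown sits.

Compound 2 (`O=C(Nc1cccc(F)c1)c1cc(=O)[nH]c2cc(Br)ccc12`) gives 8900 nM in this assay. Among the measured compounds shown here, the only measured step, an at least 2.2-fold lower number from compound 1 to compound 2 (0.35 log units; beyond the scatter), puts 3-fluorophenyl in place of 4-chlorophenyl on an amide-type nitrogen. That step lies beyond the scatter, but it exchanges the whole aryl group, so it bears only loosely on the present change.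

Compound 3 (`O=C(Nc1ccc(C(F)(F)F)cc1)c1cc(=O)[nH]c2cc(Br)ccc12`) keeps the shared core and differs from compound 1 as follows: trifluoromethyl in place of chloro on an aromatic carbon. The new group is trifluoromethyl in place of chloro on an aromatic carbon, para to a large group. For the measured compounds named here, no measured step tests this exchange, and the starting point is only a limit. No step beyond the scatter is therefore expected in this assay, and the estimated change is a number no higher from compound 1 to compound 3 (the limit leaves the size open). For compound 3 the expected value is 20000 nM, with an estimated range from 9000 nM to 45000 nM.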

Compound 3, half-maximal inhibitory concentration: > 20000 nM
Compound 3 gave a limit, no number; the forecaster's own chance of this, stated with the estimate: 60%; the middle value sits exactly at the limit.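

Compound 1 and compound 3 both stand at a limit and not a number, and the exchange of chloro for trifluoromethyl between them gives no readable step: the limit of > 20000 nM in this assay, at which 2 of the 3 values shown sit. The compounds shown leave open where compound 1 and compound 3 actually lie in this assay and whether trifluoromethyl and chloro differ there at all.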